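The source may hold more compounds than are shown below. What is called first, only, known or untested is meant among the compounds shown, and "the series" means these compounds.

Working notes on the series, read in a functional assay for antagonist activity, with Cavia porcellus as the target; a higher number here means a weaker inhibitor, a lower number a stronger inhibitor. Compound 1 `CCN(C)CC#CCCC1SCCCS1` gives > 10000000 nM, which is a limit of the assay and not a number. Compound 2 `CCN(CC)CC#CCCC1(C(O)(c2ccccc2)c2ccccc2)SCCCS1` gives 500 nM; 500 nM (2 entries) in two entries that agree. Compound 3 `CCN(CC)CC#CCCC1(C(O)(c2ccccc2)C2CCCC2)SCCCS1` gives 980 nM, from one entry. Within the data shown here, compound 3 therefore holds the only single reading, alongside one limit and one repeated entry, and its value lies within the usual scatter of that of compound 2.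

The next compound is compound 4 `CCN(CC)CC#CCCC1(C(O)(c2ccccc2)C2CCCCC2)SCCCS1`. The change from compound 3 is cyclohexyl in place of cyclopentyl on a saturated chain carbon bound to an aromatic carbon, an oxygen on a saturated carbon and a saturated ring carbon.

Among the measured compounds shown here, no measured pair isolates this swap. Compound 2 and compound 3 do differ in the group at this same carbon, yet compound 2 at 500 nM; 500 nM (2 entries) and compound 3 at 980 nM stay within the scatter. A step of no size beyond the scatter is therefore expected in this assay, with at most a slight lean toward a stronger inhibitor. The expected step, a 1.3-fold lower number from compound 3 to compound 4 (0.12 log units; within the scatter), is an estimate only. For compound 4 the estimated value is 750 nM, with an expected range of 280 nM to 2000 nM.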

Compound 4, antagonist equilibrium constant: 1140 nM
The estimate for compound 4 lay 1.5-fold (0.18 log units) below the measured number, within the range that was stated.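

In this assay, among these compounds, cyclohexyl in place of cyclopentyl gives a 1.2-fold higher number from compound 3 to compound 4 (0.07 log units; within the scatter), and this is the first pair that isolates a single swap between two saturated carbon rings on a saturated chain carbon bound to an aromatic carbon, an oxygen on a saturated carbon and a saturated ring carbon. The five-membered and six-membered rings therefore cannot be told apart at this position in this assay, so the one extra ring carbon gives no readable step here. Nothing shown bears on a cause for this outcome, and the only evidence available concerns a limit of the assay that neither compound 3 nor compound 4 reaches.

What the compounds shown leave open is how far this position reaches beyond these two rings: whether a much smaller group such as methyl or cyclopropyl, or a ring holding a nitrogen such as piperidinyl, would give a step beyond the scatter. Also open, on these data alone, is what a hydrogen or a methoxy group in place of the hydroxyl on the same carbon would do to the number in this assay.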